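Adding a Methoxy Group to Compound 1: Cytotoxicity Notes

The source may hold more compounds than are shown below. What is called first, only, known or untested is meant among the compounds shown, and "the series" means these compounds.

Measured so far:
compound 1 `COc1ccc(-c2cc(/C=C/C(=O)c3ccc(N)cc3)[nH]n2)cc1`: -16%
compound 2 `COc1ccc(C(=O)/C=C/c2cc(-c3cc(OC)c(OC)c(OC)c3)n[nH]2)cc1OC`: -92%

In a functional assay on MDA-MB-435 cells (Homo sapiens) for cytotoxicity, read by sulforhodamine B assay, with a stated time of 48 h, tested at 10 uM (on this read-out higher numbers stand for a weaker effect at the one concentration tested and lower numbers for a stronger effect), compound 1 gives -16%, the highest of the two numbers. Within the data shown here, compound 2 gives -92%, lower by a margin beyond the scatter, though the two differ in several places at once, so no single-change step is available. Compound 3 `COc1ccc(-c2cc(/C=C/C(=O)c3ccc(N)cc3)[nH]n2)cc1OC` differs from compound 1 by methoxy in place of hydrogen on an aromatic carbon, on an aromatic carbon of a six-membered aromatic ring of carbon only, ortho to a methoxy group. The expected step from compound 1 to compound 3 in this assay is a number 19 percentage points lower from compound 1 to compound 3 (beyond the scatter), a modest move toward lower numbers, held uncertain because compound 2 with -92% carries additional changes. Compound 3 is estimated at -35%, range -75% to 5%.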

Compound 3, a percentage reported as activity, at one concentration (the size of the read-out at that concentration, not a potency): -15%
For compound 3 the middle estimate is 20 percentage points below the measured one; measured number inside the range.
By their numbers in this assay, from the lowest: compound 2; then compounds 1 and 3 (each within the scatter of the next).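

In this assay, methoxy in place of hydrogen on this aromatic carbon, ortho to a methoxy group, gives a number 1 percentage points higher from compound 1 to compound 3 (within the scatter). Among these compounds, this is the first single-change reading, and at this position the added methoxy leaves the read-out within the scatter. Nothing available explains this result.

On these data alone, whether ethoxy or an amine on the same aromatic carbon would also leave the read-out unchanged remains open. Also open, as far as these compounds go, is which of the several differences in compound 2 goes with its -92%.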